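Removing the Trifluoromethyl from the Aryl Piperazine

The compounds below may be only part of what the source reports. "The series", "measured", "known", "first", "only" and "open" are said of these compounds alone.

Measured so far:
Compound 1 `CCCc1nc(-c2ccccc2)c(CNCCCN2CCN(c3cccc(C(F)(F)F)c3)CC2)o1`: 650 nM
Compound 2 `CCCc1nc(-c2ccccc2)c(CNCCN2CCN(c3ccccc3C(F)(F)F)CC2)o1`: 2100 nM

In an assay on HEK293 cells for inhibition of Voltage-dependent T-type calcium channel subunit alpha-1G (Homo sapiens), read by patch clamp (a higher number here means a weaker inhibitor, a lower number a stronger inhibitor), compound 2 gives 2100 nM, the higher of the two numbers, while compound 1 gives 650 nM. Compound 3 `CCCc1nc(-c2ccccc2)c(CNCCN2CCN(c3ccccc3)CC2)o1` differs from compound 2 by one change: hydrogen in place of trifluoromethyl on an aromatic carbon. For the measured compounds named here, no step between measured compounds shows what this change does. A modest rise in the number is expected, and the step of a 1.7-fold higher number from compound 2 to compound 3 (0.22 log units; within the scatter) is an estimate that may not reach beyond the scatter. For compound 3 the expected value is 3500 nM, with a range from 1200 nM to 10000 nM.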

Compound 3, half-maximal inhibitory concentration: 10300 nM
For compound 3 the middle estimate is 2.9-fold (0.47 log units) below the measured one; measured number above the stated range.
By their numbers in this assay, from the lowest: compound 1; then compound 2; then compound 3.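

In this assay, trifluoromethyl on this aromatic carbon proves to matter: hydrogen in its place gives a 4.9-fold higher number from compound 2 to compound 3 (0.69 log units; beyond the scatter). The plain phenyl of compound 3 is thus a clearly weaker inhibitor than the 2-(trifluoromethyl)phenyl of compound 2. Nothing available here explains the size of this step.

Going by these compounds, it remains open whether a chlorine atom, a methoxy group or a nitrile on the same carbon would match trifluoromethyl, and what the same change to hydrogen would do in compound 1.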